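The source may hold more compounds than are shown below. What is called first, only, known or untested is meant among the compounds shown, and "the series" means these compounds.

Measured so far in a functional assay on MCF7 cells (Homo sapiens) for cytotoxicity, read by MTT assay, with a stated time of 48 h; on this read-out lower numbers stand for stronger inhibition and higher numbers for weaker inhibition:
- compound 1, `COc1ccc(/C=N/NC(=O)CSc2nnc(-c3ccncc3)o2)cc1`: 17600 nM
- compound 2, `COc1cccc(/C=N/NC(=O)CSc2nnc(-c3ccncc3)o2)c1`: 13800 nM
- compound 3, `O=C(CSc1nnc(-c2ccncc2)o1)N/N=C/c1ccccc1[N+](=O)[O-]`: 35600 nM

Compound 3 stands highest of the three numbers in this assay; compound 1 is nearest and compound 2 furthest, the two methoxy compounds lying within the scatter of one another (a 1.3-fold lower number from compound 1 to compound 2 (0.11 log units; within the scatter)).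

The next compound, compound 4 (`O=C(CSc1nnc(-c2ccncc2)o1)N/N=C/c1cc(Cl)ccc1O`), is still to be measured in this assay. The change from compound 3 is 5-chloro-2-hydroxyphenyl in place of 2-nitrophenyl on a carbon with a double bond to nitrogen.

Going by the values given here, no measured step touches a hydroxyl or a chlorine on this ring, so there is no direct precedent. What bears on the step is only the reverse direction of the two changes already seen: a 2.0-fold higher number from compound 1 to compound 3 (0.31 log units; beyond the scatter) and a 2.6-fold higher number from compound 2 to compound 3 (0.41 log units; beyond the scatter), both modest, both putting the 2-nitrophenyl at the high end. Leaving the 2-nitrophenyl for another aryl variant has thus, in both recorded cases, gone with a lower number, and a modest drop of the same order is the working expectation, though a step within the scatter cannot be ruled out.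

For compound 4 the estimate in this assay is 22000 nM, with a range of 9000 nM to 50000 nM, which corresponds to an expected 1.6-fold lower number from compound 3 to compound 4 (0.21 log units; within the scatter).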

Compound 4, half-maximal inhibitory concentration: 5830 nM
Beside the measured number, compound 4's estimate is 3.8-fold (0.58 log units) above it; the measured number lies below the stated range.
By their numbers in this assay, from the lowest: compound 4; then compounds 2 and 1 (each within the scatter of the next); then compound 3.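

In this assay, the 5-chloro-2-hydroxyphenyl group on this carbon gives the first clear separation from both methoxyphenyl compounds, with a 3.0-fold lower number from compound 1 to compound 4 (0.48 log units; beyond the scatter) and a 2.4-fold lower number from compound 2 to compound 4 (0.37 log units; beyond the scatter), while those two remain within the scatter of each other. The largest step yet seen at this position is a 6.1-fold lower number from compound 3 to compound 4 (0.79 log units; beyond the scatter), which widens the span of numbers reached by changing this aryl group alone and places compound 4 lowest of the four, with its steps to all three others beyond the scatter. The change also swaps a group with no hydrogen-bond donor for one that has a hydrogen-bond donor, but no measurement on hand accounts for the size or direction of the step.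

The hydroxyl and the chlorine enter together, so the compounds shown leave open how a phenyl carrying only the hydroxyl or only the chlorine would stand against compound 4. Also open, going by these compounds, is how an amine or a carboxylic acid on this ring would read in this assay.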